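The source may report more compounds than this note shows. Statements on the series, on what has been measured and on what is new or still open speak of the compounds shown alone.

Measured compounds:
Compound 1, `CCCCC#Cc1nc(NC2CC2)c2ncn([C@H]3[C@H](O)[C@H](O)[C@@H]4C[C@@H]43)c2n1`: 39 nM
Compound 2, `CCCCC#Cc1nc(NCC)c2ncn([C@H]3[C@H](O)[C@H](O)[C@@H]4C[C@@H]43)c2n1`: 176 nM

In an assay on RBL-2H3 cells for displacement of a labelled ligand from adenosine receptor A3 (Rattus norvegicus), with a stated time of 60 min (a higher number here means a weaker inhibitor, a lower number a stronger inhibitor), compound 2 gives the higher of the two numbers shown, which means it is the weaker of the pair. Among the measured compounds shown here, its only neighbour is compound 1, and the step between them, a 4.5-fold higher number from compound 1 to compound 2 (0.65 log units; beyond the scatter), came from swapping the group on the nitrogen on an aromatic ring. For the measured compounds named here, that single step is the only measured evidence here, and it shows that changing the group at that nitrogen can move the number beyond the scatter.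

Compound 3, `CCCCC#Cc1nc(NCc2cccc(Cl)c2)c2ncn([C@H]3[C@H](O)[C@H](O)[C@@H]4C[C@@H]43)c2n1`, differs from compound 2 at the same side of the molecule: 3-chlorophenyl in place of methyl on a saturated chain carbon bound to a nitrogen on an aromatic ring. Going by the values given here, no measured pair covers a change of this kind, a large ring-bearing group entering in place of methyl on the saturated chain carbon, so the direction cannot be read off the data directly. Because of a 4.5-fold higher number from compound 1 to compound 2 (0.65 log units; beyond the scatter) a shift beyond the scatter is plausible; on balance a lower number is expected, with a step of an 8.8-fold lower number from compound 2 to compound 3 (0.94 log units; beyond the scatter). Compound 3 is therefore estimated at 20 nM, within a range of 4 nM to 100 nM.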

Compound 3, inhibition constant: 10.7 nM
For compound 3 the middle estimate is 1.9-fold (0.27 log units) above the measured one; the measured number falls inside the stated range.
By their numbers in this assay, from the lowest: compound 3; then compound 1; then compound 2.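

This position on the shared core accepts much more than a small alkyl or cycloalkyl group. In this assay, the move from ethyl to 3-chlorobenzyl on the nitrogen gives a 16-fold lower number from compound 2 to compound 3 (1.22 log units; beyond the scatter), a larger shift than the one seen earlier with ethyl and cyclopropyl, and it brings in one six-membered aromatic ring of carbon only. Swapping cyclopropyl directly for 3-chlorobenzyl gives a 3.6-fold lower number from compound 1 to compound 3 (0.56 log units; beyond the scatter), so compound 3 is the strongest inhibitor of the set shown, with its steps to both other compounds beyond the scatter, although nothing here gives a measured reason for this gain in binding.

The compounds shown leave open whether the gain comes from the aromatic ring alone or also needs the chlorine, a question that a plain benzyl group on the same nitrogen would address, as would a 3-fluorobenzyl or 3-bromobenzyl group for the choice of halogen. They also leave open how the number responds to a longer chain carrying the ring, such as a 2-phenylethyl group on that nitrogen.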